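The compounds below may be only part of what the source reports. "The series", "measured", "known", "first", "only" and "open" are said of these compounds alone.

Compound 1 `COc1ccc(-c2c(C#N)c(-c3ccccc3)nc3c2c(-c2ccccc2)nn3-c2ccccc2)cc1OC`: > 25000 nM
Compound 2 `N#Cc1c(-c2ccc(Cl)cc2)nc2c(c(-c3ccccc3)nn2-c2ccccc2)c1-c1ccc(O)cc1`: 25100 nM

Both compounds were tested in a functional assay on MV4-11 cells (Homo sapiens) for antiproliferative activity, read by resazurin assay, with a stated time of 72 h; a lower number here means a stronger inhibitor, a higher number a weaker inhibitor. For compound 1 the value > 25000 nM is a limit of the assay rather than a measured number, so compound 1 sits at the edge of what this assay can report (the limit of > 25000 nM in this assay, at which 1 of the 2 values shown sits). Compound 2 gives 25100 nM in this assay, which shows that compound 2 is a weak inhibitor of the growth of these cells.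

Compound 3 `COc1cc(-c2c(C#N)c(-c3ccccc3)nc3c2c(-c2ccccc2)nn3-c2ccccc2)ccc1O` is the compound still to be measured. It differs from compound 1 in one place: hydrogen in place of methyl on an oxygen on an aromatic ring. Among the measured compounds shown here, no pair of measured compounds differs by exactly this change, so the size of the step can only be guessed. Since compound 2, which also carries a hydroxy group, gives 25100 nM in this assay, a step of modest size in either direction is expected, most likely none beyond the usual scatter, so that the step from compound 1 to compound 3 is estimated as an at least 1.2-fold lower number from compound 1 to compound 3 (0.09 log units; that floor lies within the scatter). Compound 3 is therefore expected to give about 20000 nM in this assay, with a plausible range from 5000 nM to 60000 nM.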

Compound 3, half-maximal inhibitory concentration: > 50000 nM
Compound 3 gave a limit, no number (the forecaster's own chance of this, stated with the estimate: 50%); at least 2.5-fold (0.39 log units) between middle value and limit.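

Compound 1 and compound 3 both give a limit in this assay rather than a measured number, so the size of the step between them cannot be read. The compounds shown leave open whether hydrogen in place of methyl on this oxygen changes the activity of the compound at all, and in which direction.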